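The source may report more compounds than this note shows. Statements on the series, on what has been measured and on what is new or still open speak of the compounds shown alone.

Working notes on the series. Of the compounds shown here, three on the shared core have been measured: compound 1 `COc1cc2c(cc1OC)C(=O)C(CC1CCN(C(=S)Nc3ccc([N+](=O)[O-])cc3)CC1)C2`, compound 2 `COc1cc2c(cc1OC)C(=O)C(CC1CCN(C(=S)Nc3ccccc3Cl)CC1)C2` and compound 3 `CCCNC(=S)N1CCC(CC2Cc3cc(OC)c(OC)cc3C2=O)CC1`. In a functional assay on the whole organism (strain Swiss albino) with Mus musculus as the target, in the maximal electroshock model, with a stated time of 4 h (a lower number here means that less compound is needed, a higher number that more compound is needed for the effect), compound 1 gives 300 mg/kg. In this assay compound 2 gives 300 mg/kg, and compound 3 gives 300 mg/kg. The steps between them are no change at the digits printed from compound 1 to compound 2 (within the scatter), no change at the digits printed from compound 1 to compound 3 (within the scatter) and no change at the digits printed from compound 2 to compound 3 (within the scatter), so compound 3 stands level with compounds 1 and 2 at the digits reported, with no separation among the three.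

Compound 4 `CCCCNC(=S)N1CCC(CC2Cc3cc(OC)c(OC)cc3C2=O)CC1` is the next candidate. The change is methyl in place of hydrogen on a saturated chain carbon, three bonds along the chain from an amide-type nitrogen; read one bond further out it is propyl to butyl on the amide-type nitrogen. Among the compounds with values here, no measured step alters a chain in this way; the nearest comparisons are the swaps of the group on the amide-type nitrogen, which all stayed within the scatter. On that basis a step beyond the scatter is not expected, and compound 4 is expected to show no change at the digits printed from compound 3 to compound 4 (within the scatter) in this assay. The estimate for compound 4 is 300 mg/kg, with a range from 100 mg/kg to 600 mg/kg.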

Compound 4, minimum effective dose: 100 mg/kg
Compound 4: the middle estimate sits 3.0-fold (0.48 log units) above what was measured; measured number inside the range.
By their numbers in this assay, from the lowest: compound 4; then compounds 1, 2 and 3 (each within the scatter of the next).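

In this assay, within the data shown here, the change from propyl to butyl on the amide-type nitrogen is the only step that lies beyond the scatter: methyl in place of hydrogen on a saturated chain carbon, three bonds along the chain from an amide-type nitrogen, gives a 3.0-fold lower number from compound 3 to compound 4 (0.48 log units; beyond the scatter) and shows that this position can respond to a single added carbon. Butyl also separates from the two aryl groups, with a 3.0-fold lower number from compound 2 to compound 4 (0.48 log units; beyond the scatter) for the swap from 2-chlorophenyl and a 3.0-fold lower number from compound 1 to compound 4 (0.48 log units; beyond the scatter) for the swap from 4-nitrophenyl, whereas 2-chlorophenyl, 4-nitrophenyl and propyl showed no separation from one another. No evidence on hand accounts for this step.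

One modest step does not establish a trend with chain length. On these data alone, whether a longer chain such as pentyl or hexyl, a branched chain such as isobutyl, or a cyclohexyl ring on the same nitrogen would lower the number further remains open.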